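Trimming the Carbamate Side Chain of Compound 2

The source may hold more compounds than are shown below. What is called first, only, known or untested is meant among the compounds shown, and "the series" means these compounds.

Compound 2 `C[C@@H]1CN(C(=O)c2nc(Nc3cc(C4CC4)[nH]n3)c3cc(Cl)ccc3n2)CCN1C(=O)OCOC(=O)C(C)(C)C` gives 60.5% in an assay for inhibition of serine/threonine-protein kinase PAK 4 (Homo sapiens), read by FRET and Z'-LYTE, with a stated time of 60 min, tested at 50 uM, in the presence of a further agent that is not named here (a higher number here means a stronger effect of the compound at the concentration tested, a lower number a weaker effect), which is the lowest of the two numbers in hand. Within the data shown here, compound 1 `CC(OC(=O)C(C)C)OC(=O)N1CCN(C(=O)c2nc(Nc3cc(C4CC4)[nH]n3)c3cc(Cl)ccc3n2)C[C@H]1C` gives 71.7% in this assay, and the one measured step, a number 11.2 percentage points lower from compound 1 to compound 2 (beyond the scatter), shows that changing the group on this oxygen shifted the inhibition by a modest amount. Compound 3 `CC(C)OC(=O)N1CCN(C(=O)c2nc(Nc3cc(C4CC4)[nH]n3)c3cc(Cl)ccc3n2)C[C@H]1C` differs from compound 2 by isopropyl in place of (((tert-butyl)carbonyl)oxy)methyl on an oxygen next to a carbonyl group. Among the measured compounds shown here, that single measured step is the only one that touches the same place, and no measured compound carries a plain alkyl group there, so the direction of the coming step is open. A step of no more than modest size is therefore expected, with a number 5.5 percentage points higher from compound 2 to compound 3 (within the scatter) as the expected move from compound 2 to compound 3. Compound 3 is expected to give 66% in this assay, within a range from 45% to 85%.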

Compound 3, a percentage reported as inhibition, at one concentration (the size of the read-out at that concentration, not a potency) in the serine/threonine-protein kinase PAK 4 assay: 91.2%
The estimate for compound 3 lay 25.2 percentage points below the measured number; the measured number lies above the stated range.
By their numbers in the serine/threonine-protein kinase PAK 4 assay, from the lowest: compound 2; then compound 1; then compound 3.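

In the serine/threonine-protein kinase PAK 4 assay compound 3 gives 91.2%: set against the two chains that carry an ester, isopropyl gives a large gain (a number 30.7 percentage points higher from compound 2 to compound 3 (beyond the scatter)) and a modest one over the other chain (a number 19.5 percentage points higher from compound 1 to compound 3 (beyond the scatter)). The earlier pair showed only that swapping one longer chain for another shifts the inhibition, whereas this result shows that the ester part is not needed for strong inhibition at this oxygen, and that among these three compounds the simple isopropyl carbamate ranks highest. In a physicochemical assay, read by HPLC, in phosphate buffer, with a stated time of 2 h, at pH 7.4 (a lower number here means that less of the compound is left, a higher number that more of the compound is left), compound 2 gives 97.7% and compound 3 gives 99%. In the physicochemical assay the same change stays within the scatter (a number 1.3 percentage points higher from compound 2 to compound 3 (within the scatter)), so the gain in inhibition has no matching difference in how much compound is left.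

From the compounds shown here alone, whether an ethyl group, a butyl chain or a chain ending in an amine would serve as well on this oxygen remains open. Nothing at hand explains why the inhibition rises with isopropyl.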